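The source may hold more compounds than are shown below. What is called first, only, known or untested is meant among the compounds shown, and "the series" means these compounds.

Compound 1 `Cc1cc(S(=O)(=O)N2C=CNC(=O)[C@H]2CC(=O)N[C@H]2CCNCC2(C)C)c(C)cc1Cl` gives 0.31 nM in an in vitro functional assay on cells for antagonist activity at B1 bradykinin receptor (Homo sapiens), read by luminescence and calcium flux, with a stated time of 2 h; a higher number here means a weaker inhibitor, a lower number a stronger inhibitor. Compound 2 `Cc1cc(S(=O)(=O)N2C=CNC(=O)[C@H]2CC(=O)N[C@H]2CCN(C)CC2(C)C)c(C)cc1Cl` gives 0.28 nM in this assay.

Within the data shown here, compound 2 holds the lower of the two numbers, yet the only measured step, a 1.1-fold lower number from compound 1 to compound 2 (0.04 log units; within the scatter), leaves the two compounds indistinguishable. Compound 3 `Cc1cc(S(=O)(=O)N2C=CNC(=O)[C@H]2CC(=O)N2CCC[C@H](N3CCCC3)C2)c(C)cc1Cl` differs from compound 2 by a group of 11 heavy atoms (9 carbon, 2 nitrogen; one five-membered non-aromatic ring with 1 hetero atom, one six-membered non-aromatic ring with 1 hetero atom) in place of a group of 10 heavy atoms (8 carbon, 2 nitrogen; one six-membered non-aromatic ring with 1 hetero atom), on a carbonyl carbon. Among the measured compounds shown here, that step is a methyl for hydrogen exchange and does not bear on this larger change, so no measured step informs it; the change is expected to bring a modest loss, a 4.3-fold higher number from compound 2 to compound 3 (0.63 log units; beyond the scatter). Compound 3 is therefore estimated at 1.2 nM, with a range from 0.25 nM to 6 nM.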

Compound 3, half-maximal inhibitory concentration: 38 nM
Beside the measured number, compound 3's estimate is 32-fold (1.50 log units) below it, and the stated range ends below it.
By their numbers in this assay, from the lowest: compounds 2 and 1 (each within the scatter of the next); then compound 3.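

Where the methyl for hydrogen exchange on the ring nitrogen left the number unmoved, the change on the carbonyl carbon is not tolerated in this assay: it gives a 140-fold higher number from compound 2 to compound 3 (2.13 log units; beyond the scatter) and a 120-fold higher number from compound 1 to compound 3 (2.09 log units; beyond the scatter). Among these compounds, the result thus shows that this position is far more sensitive than the amine nitrogen of the earlier compounds. Nothing measured here accounts for the loss. The compounds shown do not separate the effect of the entering group's five-membered ring from that of its six-membered ring. From the compounds shown here alone, whether a dimethylamino group in place of the five-membered ring would recover the number remains open.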